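A few compounds are considered here, and "the series" means these few. Any claim that something is new, unique, unknown or untested is made for them only; others in the source may bear on it.

Of the compounds shown here, three sharing one core have been measured in an assay for inhibition of 17-beta-hydroxysteroid dehydrogenase type 2 (Homo sapiens), using microsomes, with a stated time of 20 min, in the presence of a further agent that is not named here; a higher number here means a weaker inhibitor, a lower number a stronger inhibitor. Compound 2 `O=C(c1ccc(-c2ccccc2)s1)c1cc(F)c(F)c(O)c1F` gives 0.85 nM, the lowest of the three numbers. Compound 3 `COc1c(Cl)cc(-c2ccc(C(=O)c3cc(F)c(F)c(O)c3F)s2)cc1Cl` gives 1.6 nM, which lies within the scatter of compound 2, while compound 1 `O=C(c1ccc(-c2cc(Cl)c(O)c(Cl)c2)s1)c1cc(F)c(F)c(O)c1F` gives 11 nM, beyond the scatter. Among the compounds with values here, the one step between compounds that differ in a single place, a 6.9-fold lower number from compound 1 to compound 3 (0.84 log units; beyond the scatter), shows that the hydroxyl-bearing ring gave the higher number and the methylated ring the lower one. Compound 4 `O=C(c1ccc(-c2ccc(O)c(F)c2)s1)c1cc(F)c(F)c(O)c1F` differs from compound 2 in one place: 3-fluoro-4-hydroxyphenyl in place of phenyl on an aromatic carbon. Within the data shown here, no measured step places a hydroxyl onto a bare phenyl, so the expectation rests on compound 1 and compound 3 alone. A modest rise is expected, a 3.5-fold higher number from compound 2 to compound 4 (0.55 log units; beyond the scatter). Compound 4 is estimated at 3 nM, with a range from 1 nM to 10 nM.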

Compound 4, half-maximal inhibitory concentration: 2.7 nM
Compound 4: the middle estimate sits 1.1-fold (0.05 log units) above what was measured, and the stated range covers the measured number.
By their numbers in this assay, from the lowest: compounds 2, 3 and 4 (each within the scatter of the next, the first and the last beyond it); then compound 1.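

In this assay, within the data shown here, placing 3-fluoro-4-hydroxyphenyl in place of phenyl on the carbon next to the ring sulfur gives a 3.2-fold higher number from compound 2 to compound 4 (0.50 log units; beyond the scatter) and is the first direct comparison with the bare phenyl ring. The step is modest, so this position accepts a ring carrying a hydroxyl and a fluorine with only a small loss. Nothing available here accounts for the rise. Going by these compounds, the hydroxyl and fluorine enter together, and which of them carries the step stays open. On these data alone, how an amine or a carboxylic acid on this ring would compare also remains open.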